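Metabolic stability on moving to a hydroxy-dioxothianyl amide

The compounds below may be only part of what the source reports. "The series", "measured", "known", "first", "only" and "open" are said of these compounds alone.

Compound 1 `CCC[C@]1(C(=O)N2CC[C@](c3ccc(C(F)(C(F)(F)F)C(F)(F)F)cc3)(S(=O)(=O)c3ccc(F)cc3)C2)CC[C@H](C(=O)O)CC1` has no single number in an ADME assay on microsomes from liver (Mus musculus) for metabolic stability, with a stated time of 10 min; a lower number here means that less of the compound is left, a higher number that more of the compound is left; its entry there is recorded as "not determined" (no result reported). Two close relatives from the same series are measured: compound 2 `O=C(O)C1CCC(O)(C(=O)N2CC[C@](c3ccc(C(F)(C(F)(F)F)C(F)(F)F)cc3)(S(=O)(=O)c3ccc(F)cc3)C2)CC1` gives 99%; 98% (2 entries) in this assay, and compound 3 `NC(=O)[C@H]1CC[C@H](C(=O)N2CC[C@](c3ccc(C(F)(C(F)(F)F)C(F)(F)F)cc3)(S(=O)(=O)c3ccc(F)cc3)C2)CC1` gives 100%. The repeat entries of compound 2 agree closely (the several entries of compound 2 in this assay, 99%; 98% (2 entries)). Compound 4 `O=C(N1CC[C@](c2ccc(C(F)(C(F)(F)F)C(F)(F)F)cc2)(S(=O)(=O)c2ccc(F)cc2)C1)C1(O)CCS(=O)(=O)CC1` differs from compound 1 in one place: 4-hydroxy-1,1-dioxothian-4-yl in place of 4-carboxy-1-propylcyclohexyl on a carbonyl carbon. For the measured compounds named here, no measured step links compound 1 to compound 4, so any difference in this assay remains to be seen; the present values suggest that compounds of this core sit near the top of the scale, and a shift beyond the usual scatter is not expected. Compound 4 is therefore expected to give about 97%, within 88% to 100%, because compound 2 gives 99%; 98% (2 entries).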

Compound 4, percent of the compound remaining: 90%
Compound 4: the middle estimate sits 7 percentage points above what was measured; the measured number falls inside the stated range.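

In this assay, for the compounds shown here, placing 4-hydroxy-1,1-dioxothian-4-yl in place of 4-carbamoylcyclohexyl on the carbonyl carbon gives a number 10 percentage points lower from compound 3 to compound 4 (within the scatter) and the sentence stands as the only readable step here. Among the compounds with values, compound 4 is the first with a hetero atom in this six-membered ring, and this change stays within the usual scatter. The step from compound 1 to compound 4 cannot be read: compound 1 has no single number.

Nothing shown gives a cause for this result. From the compounds shown here alone, whether an amine in place of the hydroxy group of 4-hydroxy-1,1-dioxothian-4-yl would leave the value of compound 4 within the scatter remains open.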